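Benzyl for Phenyl on the Amide Nitrogen: Cytotoxicity Outlook

The source may hold more compounds than are shown below. What is called first, only, known or untested is meant among the compounds shown, and "the series" means these compounds.

Compound 1 `O=C(Nc1ccccc1)c1c(NO)cc(-c2ccc(F)cc2)oc1=O` — 10300 nM
Compound 2 `COc1ccc(-c2cc(NO)c(C(=O)Nc3ccccc3)c(=O)o2)cc1` — 16200 nM

Among the compounds with values here, in an ADME assay on Huh-7 cells (Homo sapiens) for cytotoxicity, read by a luciferase reporter and WST assay, with a stated time of 3 days (on this read-out higher numbers stand for lower toxicity in this test and lower numbers for higher toxicity in this test), compound 1 gives 10300 nM, the lower of the two numbers known, but the only step, a 1.6-fold higher number from compound 1 to compound 2 (0.20 log units; within the scatter), stays within the scatter, so compounds 1 and 2 cannot be told apart. Compound 3 `O=C(NCc1ccccc1)c1c(NO)cc(-c2ccc(F)cc2)oc1=O` differs from compound 1 by benzyl in place of phenyl on an amide-type nitrogen. Within the data shown here, no measured step touches this change; the one step known concerns a different part of the molecule. With nothing to point either way, compound 3 is expected to stay near compound 1: a 1.0-fold lower number from compound 1 to compound 3 (0.01 log units; within the scatter). The estimate for compound 3 in this assay is 10000 nM, within 4000 nM to 25000 nM.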

Compound 3, half-maximal cytotoxic concentration: > 20000 nM
Compound 3: no number, only a limit (the forecaster's own chance of this, stated with the estimate: 10%); middle value at least 2.0-fold (0.30 log units) away from the limit.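

Changing phenyl to benzyl on the amide-type nitrogen is the first change shown at this position, and in this assay it gives an at least 1.9-fold higher number from compound 1 to compound 3 (0.28 log units; that floor lies within the scatter). Compound 3 reads > 20000 nM, which is a limit of the assay and not a number. The position therefore accepts benzyl with no sign of higher toxicity in this test, though the floor of this step does not by itself separate the two compounds.

On these data alone, how far compound 3 truly lies from compound 1 stays open. So does whether a longer chain such as phenethyl, or a carboxylic acid on the benzyl group, would read the same way.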